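Swapping one side chain on an inactive-looking compound

A few compounds are considered here, and "the series" means these few. Any claim that something is new, unique, unknown or untested is made for them only; others in the source may bear on it.

Compound 1 (`COc1ccc(-c2cc3c(OC)ccc(OC)c3nc2O)cc1`) gives 10000 nM
Compound 2 (`COc1cc(OC)c2cc(-c3ccc(OCc4ccccc4)cc3)c(O)nc2c1`) gives 10000 nM
Compound 3 (`CCN(CC)C(=O)Cn1c(=O)c(-c2ccc(OC)cc2)cc2c(OC)cc(OC)cc21`) gives 10000 nM

In a functional assay on U-373MG ATCC cells for cytotoxicity against U373 MG (Homo sapiens), read by colorimetric assay and MTT assay (on this read-out lower numbers stand for stronger inhibition and higher numbers for weaker inhibition), compound 3 gives 10000 nM and stands level with compound 1 and compound 2. Compound 4 (`COc1ccc(-c2cc3c(OC)cc(OC)cc3n(CCC#N)c2=O)cc1`) differs from compound 3 in one place (cyanomethyl in place of diethylcarbamoyl on a saturated chain carbon bound to an aromatic nitrogen): cyanomethyl in place of diethylcarbamoyl on a saturated chain carbon bound to an aromatic nitrogen. Among the compounds with values here, the measured compounds offer no step between them to learn from, so the only guide is compound 3 at 10000 nM and no change beyond the scatter is expected. The expected step of no change at the digits printed from compound 3 to compound 4 (within the scatter) stays within the scatter, with no direction favoured. Compound 4 is estimated at 10000 nM (expected range 4000 nM to 20000 nM).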

Compound 4, half-maximal inhibitory concentration: 10000 nM
The estimate for compound 4 equals the measured number at the digits printed; low and high end bracket the measured number.
By their numbers in this assay, from the lowest: compounds 1, 2, 3 and 4 (each within the scatter of the next).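

Replacing diethylcarbamoyl with the smaller cyanomethyl on a saturated chain carbon bound to an aromatic nitrogen gives, in this assay, no change at the digits printed from compound 3 to compound 4 (within the scatter). Within the data shown here, this is the first one-place comparison in the set, and it shows that this swap of side chain, with its carbonyl traded for a nitrile, leaves the number where it was. No measurement shown explains this result. On these data alone, whether a side chain ending in an amine or a carboxylic acid would lower the number at this place stays open.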